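Replacing the 3-methoxybenzyl group of compound 2

The compounds below may be only part of what the source reports. "The series", "measured", "known", "first", "only" and "open" are said of these compounds alone.

Measured so far in a functional assay on Jurkat cells (Homo sapiens) for inhibition, read by CCK-8 assay, with a stated time of 48 h; on this read-out lower numbers stand for stronger inhibition of growth and higher numbers for weaker inhibition of growth:
compound 1 `CN1CCN(c2ccc(Nc3ncc(Cl)c(NCc4ccc(C(F)(F)F)cc4)n3)nc2)CC1`: 7960 nM
compound 2 `COc1cccc(CNc2nc(Nc3ccc(N4CCN(C)CC4)cn3)ncc2Cl)c1`: 73400 nM

Of these two, compound 2 has the higher number, at 73400 nM. Compound 3 `Cc1cccc(Nc2nc(Nc3ccc(N4CCN(C)CC4)cn3)ncc2Cl)c1` carries 3-methylphenyl in place of 3-methoxybenzyl on a nitrogen on an aromatic ring. Cut one bond further out, this reads (3-methoxybenzyl)amino to (3-methylphenyl)amino. Within the data shown here, only one measured step bears on this change, and only indirectly: a 9.2-fold higher number from compound 1 to compound 2 (0.96 log units; beyond the scatter). Among the measured compounds shown here, no measured compound has the 3-methylphenyl group on that nitrogen, so the direction remains uncertain. For the measured compounds named here, with compound 1 at 7960 nM as the sole comparison, a modest move towards a lower number in this assay is expected. The estimated step is a 3.7-fold lower number from compound 2 to compound 3 (0.56 log units; beyond the scatter). Compound 3 is expected to give 20000 nM, with an estimated range of 4000 nM to 90000 nM.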

Compound 3, concentration for 50% growth inhibition: 15300 nM
Compound 3: middle estimate off by 1.3-fold (0.12 log units), on the high side; low and high end bracket the measured number.
By their numbers in this assay, from the lowest: compounds 1 and 3 (each within the scatter of the next); then compound 2.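

In this assay, moving from 3-methoxybenzyl to 3-methylphenyl on this nitrogen gives a 4.8-fold lower number from compound 2 to compound 3 (0.68 log units; beyond the scatter), showing that the number at this position responds to a change that removes the chain carbon and replaces the methoxy group with methyl. The second comparison gives a 1.9-fold higher number from compound 1 to compound 3 (0.28 log units; within the scatter), so 3-methylphenyl and 4-(trifluoromethyl)benzyl cannot be told apart here, and an aromatic ring bound directly to this nitrogen matches the better of the two benzyl-type groups seen so far. No experimental evidence is available to explain either step.

Because both features change at once, the compounds shown do not separate the contribution of the chain carbon from that of the ring substituent. Open too, going by these compounds, is how 3-methylbenzyl, 3-methoxyphenyl or a longer chain such as 2-phenylethyl would behave on this nitrogen.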